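Replacing the group on the carbonyl carbon of compound 3

A few compounds are considered here, and "the series" means these few. Any claim that something is new, unique, unknown or untested is made for them only; others in the source may bear on it.

In a physicochemical assay for lipophilicity, read by HPLC, in phosphate buffer, measured as octanol-water partition, with a stated time of 1 h, at pH 7.4 (on this read-out higher numbers stand for higher lipophilicity and lower numbers for lower lipophilicity), compound 3 (`C[C@@]1(c2cc(NC(=O)c3coc(CF)n3)ccc2F)C=C(CF)OC(N)=N1`) gives 2.2, the lowest of three measured numbers. Compound 1 (`C[C@@]1(c2cc(NC(=O)c3cnc(OCF)cn3)ccc2F)C=C(CF)OC(N)=N1`) stands at 2.6 and compound 2 (`C[C@@]1(c2cc(NC(=O)c3coc(C(F)F)n3)ccc2F)C=C(CF)OC(N)=N1`) at 2.6, and each of these lies beyond the scatter from compound 3.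

The move to compound 4 (`COc1cc(C#N)cnc1C(=O)Nc1ccc(F)c([C@]2(C)C=C(CF)OC(N)=N2)c1`) exchanges one group on a carbonyl carbon: 5-cyano-3-methoxypyridin-2-yl in place of 2-(fluoromethyl)-1,3-oxazol-4-yl on a carbonyl carbon. Among the measured compounds shown here, no measured compound carries 5-cyano-3-methoxypyridin-2-yl, so the evidence is indirect. For the measured compounds named here, exchanging 5-(fluoromethoxy)pyrazin-2-yl for 2-(fluoromethyl)-1,3-oxazol-4-yl gave a number 0.40 log units lower from compound 1 to compound 3 (beyond the scatter), the closest precedent, as compound 1 also has a six-membered aromatic ring at this place. Exchanging fluoro for hydrogen within the five-membered group gave a number 0.40 log units lower from compound 2 to compound 3 (beyond the scatter), while the other group exchange gave no change at the digits printed from compound 1 to compound 2 (within the scatter). These steps suggest that compound 3 sits low among its neighbours, so a rise of similar size is expected in this assay, namely a number 0.40 log units higher from compound 3 to compound 4 (beyond the scatter). Compound 4 is estimated at 2.6, with an expected range from 2.2 to 3.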

Compound 4, distribution coefficient: 1.9
Compound 4: middle estimate off by 0.70 log units, on the high side, outside the stated range (below it).
By their numbers in this assay, from the lowest: compounds 4 and 3 (each within the scatter of the next); then compounds 1 and 2 (each within the scatter of the next).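

In this assay, 5-cyano-3-methoxypyridin-2-yl on the carbonyl carbon gives a number 0.30 log units lower from compound 3 to compound 4 (within the scatter), so this six-membered aromatic ring does not separate from the five-membered 2-(fluoromethyl)-1,3-oxazol-4-yl group. The same group gives a number 0.70 log units lower from compound 2 to compound 4 (beyond the scatter) and a number 0.70 log units lower from compound 1 to compound 4 (beyond the scatter), and the last step joins two six-membered aromatic rings, so among these four compounds ring size alone does not set the number at this position. Nothing at hand accounts for this outcome.

Compound 4 brings the pyridine ring, the cyano group and the methoxy group together, so the compounds shown do not separate their shares in the step. Going by these compounds, whether a pyridin-2-yl group carrying only the cyano group or only the methoxy group, or an amine in place of the cyano group, would read the same remains open.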